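Swapping Ethoxy for Chloro on a Fused Ring

The source may report more compounds than this note shows. Statements on the series, on what has been measured and on what is new or still open speak of the compounds shown alone.

Of the compounds shown here, three have been measured in a functional assay on T47D cells (Homo sapiens) for activation; on this read-out lower numbers stand for an effect already at smaller amounts and higher numbers for an effect only at larger amounts of compound. Compound 1 `COc1cc(C2C(C#N)=C(N)Oc3c2ccc(C)c3C)cc(Br)c1OC` gives 46000000 nM, compound 2 `CCOc1ccc2c(c1)OC(N)=C(C#N)C2c1cc(Br)c(OC)c(OC)c1` gives 64000000 nM, and compound 3 `COc1cc(C2C(C#N)=C(N)Oc3c2ccc(N)c3N)cc(Br)c1O` gives 23000000 nM. Compound 2 thus has the highest number of the three; its gap to compound 1 lies within the usual scatter, while its gap to compound 3 lies beyond it. Compound 4 `COc1cc(C2C(C#N)=C(N)Oc3cc(Cl)ccc32)cc(Br)c1OC` differs from compound 2 by chloro in place of ethoxy on an aromatic carbon. Within the data shown here, no step between measured compounds isolates this kind of change, so there is no direct precedent for it. With all three numbers this large, the change is expected to move the read-out little, if at all, beyond the scatter, and the expected step is a 1.4-fold lower number from compound 2 to compound 4 (0.15 log units; within the scatter). Compound 4 is therefore estimated at 45000000 nM, within a range from 15000000 nM to 130000000 nM.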

Compound 4, half-maximal effective concentration: 160000000 nM
Beside the measured number, compound 4's estimate is 3.6-fold (0.55 log units) below it; the measured number lies above the stated range.
By their numbers in this assay, from the lowest: compounds 3, 1 and 2 (each within the scatter of the next, the first and the last beyond it); then compound 4.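

In this assay, the step of a 2.5-fold higher number from compound 2 to compound 4 (0.40 log units; beyond the scatter) shows that chloro in place of ethoxy on this aromatic carbon is not a silent swap, even though all the numbers are already very large. The change moves the read-out beyond the scatter, towards an effect only at larger amounts of compound. Nothing available accounts for this step.

This single pair cannot separate the loss of ethoxy from the arrival of chloro. On these data alone, how fluoro, methoxy or a carboxylic acid would behave on the same carbon remains open.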